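Extending a hydroxymethyl group by one carbon

This account rests on a few compounds, and the source may have more. Where it says the series, first, only, none or still open, it means among the compounds named here.

Of the compounds shown here, three sharing one core have been measured in an ADME assay on PANC-1 cells (Homo sapiens) for cytotoxicity, read by sulforhodamine B assay, with a stated time of 48 h, tested at 10 uM; on this read-out lower numbers stand for less inhibition and higher numbers for more inhibition at the one concentration tested (going by the name of the read-out). Compound 1 `COc1nc2ccc(Br)cc2cc1C(c1ccccc1)n1cc(-c2ccc(Br)cc2)nn1` gives 10.4%, compound 2 `CCCCCCc1cn(C(c2ccccc2)c2cc3cc(Br)ccc3nc2OC)nn1` gives 6.08%, and compound 3 `COc1nc2ccc(Br)cc2cc1C(c1ccccc1)n1cc(CO)nn1` gives 15%. Compound 3 holds the highest of the three numbers, yet the steps of a number 4.6 percentage points higher from compound 1 to compound 3 (within the scatter) and a number 8.9 percentage points higher from compound 2 to compound 3 (within the scatter) both lie within the scatter, so no ranking among the three can be claimed. Compound 4 `COc1nc2ccc(Br)cc2cc1C(c1ccccc1)n1cc(CCO)nn1` differs from compound 3 by hydroxymethyl in place of hydroxy on a saturated chain carbon bound to an aromatic carbon. Among the measured compounds shown here, no measured step makes this exact change; the nearest, a number 8.9 percentage points higher from compound 2 to compound 3 (within the scatter), exchanges a far larger group and still stays within the scatter, as does a number 4.3 percentage points lower from compound 1 to compound 2 (within the scatter). Since three different groups at this position gave no shift beyond the scatter, none is expected here either, a number 2 percentage points lower from compound 3 to compound 4 (within the scatter). Compound 4 is therefore estimated at 13%, within 4% to 24%.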

Compound 4, a percentage reported as inhibition, at one concentration (the size of the read-out at that concentration, not a potency): 19.8%
Beside the measured number, compound 4's estimate is 6.8 percentage points below it, and the stated range covers the measured number.
By their numbers in this assay, from the lowest: compounds 2, 1, 3 and 4 (each within the scatter of the next, the first and the last beyond it).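

In this assay, the one-carbon extension gives a number 4.8 percentage points higher from compound 3 to compound 4 (within the scatter) and the exchange for the large aromatic group gives a number 9.4 percentage points higher from compound 1 to compound 4 (within the scatter), so neither change stands out from the scatter. Among the compounds shown here, the new finding is a number 13.7 percentage points higher from compound 2 to compound 4 (beyond the scatter), the first step at this position to pass the scatter, which shows that exchanging hexyl for 2-hydroxyethyl can shift the read-out, though only modestly. Nothing available gives a reason for that shift. Still open, as far as these compounds go, is whether a 3-hydroxypropyl chain would continue the trend or fall back. An amine or a carboxylic acid in place of the hydroxy could also show whether the hydroxy itself matters.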